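This account rests on a few compounds, and the source may have more. Where it says the series, first, only, none or still open, it means among the compounds named here.

Compound 1 `CCCCCCc1cn([C@@H]2O[C@H](CO)[C@@H](O)[C@H]2O)nn1` and compound 2 `CC(O)c1cn([C@@H]2O[C@H](CO)[C@@H](O)[C@H]2O)nn1` share one core and differ only in the group on the aromatic carbon. In a functional assay on CCRF-CEM cells (Homo sapiens) (on this read-out higher numbers stand for weaker inhibition and lower numbers for stronger inhibition), compound 1 reaches only the assay limit > 200000 nM. In this assay compound 2 likewise reaches only the limit > 200000 nM. The step that the two limits leave unreadable from compound 1 to compound 2 therefore cannot be read, and the limit of > 200000 nM in this assay, at which 2 of the 2 values shown sit, is all the series offers. Compound 3 `OC[C@H]1O[C@@H](n2cc(-c3ccc(F)cc3)nn2)[C@H](O)[C@@H]1O` carries 4-fluorophenyl in place of 1-hydroxyethyl on an aromatic carbon. Among the measured compounds shown here, no measured step bears on this change, so no direction can be set in this assay, and a further limit is the likeliest outcome. Compound 3 is estimated at 200000 nM, range 20000 nM to 400000 nM, meaning an expected step of a number no higher from compound 2 to compound 3 (the limit leaves the size open).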

Compound 3, half-maximal inhibitory concentration: 217000 nM
Compound 3: the middle estimate sits 1.1-fold (0.04 log units) below what was measured, and the stated range covers the measured number.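

In this assay, among the compounds shown here, no step to compound 3 can be read from compound 1 or compound 2, whose values are limits only. Left open is whether, in this assay, hexyl, 1-hydroxyethyl and 4-fluorophenyl differ at all in inhibition.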